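The source may report more compounds than this note shows. Statements on the series, on what has been measured and on what is new or still open speak of the compounds shown alone.

In a functional assay on DU-145 cells (Homo sapiens) for inhibition, read by trypan blue exclusion, with a stated time of 96 h (on this read-out higher numbers stand for weaker inhibition of growth and lower numbers for stronger inhibition of growth), compound 1 (`Cc1ccc(CS/C(=C/c2ccc(F)c(C)c2)C(=O)c2ccc(Cl)cc2)cc1`) gives 25000 nM and compound 2 (`Cc1ccc(CS/C(=C/c2ccc(O)c(O)c2O)C(=O)c2ccc(Cl)cc2)cc1`) gives 50000 nM while compound 3 (`Cc1ccc(CS/C(=C/c2ccc(C)s2)C(=O)c2ccc(Cl)cc2)cc1`) gives 50000 nM in the same test. Compound 3 thus stands level with compound 2 and within the scatter of compound 1. Compound 4 (`Cc1ccc(CS/C(=C/c2c[nH]c3ccc(Cl)cc23)C(=O)c2ccc(Cl)cc2)cc1`) carries 5-chloro-1H-indol-3-yl in place of 5-methylthiophen-2-yl on a double-bonded chain carbon bound to a double-bonded chain carbon. Going by the values given here, the measured exchanges at that same place are the steps that bear on it: a 2.0-fold higher number from compound 1 to compound 2 (0.30 log units; within the scatter) and a 2.0-fold higher number from compound 1 to compound 3 (0.30 log units; within the scatter) and no change at the digits printed from compound 2 to compound 3 (within the scatter) all lie within the scatter. None of them brings in 5-chloro-1H-indol-3-yl, so the guidance is indirect. Going by a 2.0-fold higher number from compound 1 to compound 3 (0.30 log units; within the scatter) and no change at the digits printed from compound 2 to compound 3 (within the scatter) as the closest guides, no step beyond the scatter is expected in this assay in either direction. The estimated change is a 1.7-fold lower number from compound 3 to compound 4 (0.22 log units; within the scatter) (within the scatter). For compound 4 the estimated value is 30000 nM (expected range 10000 nM to 70000 nM).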

Compound 4, concentration for 50% growth inhibition: 1000 nM
For compound 4 the middle estimate is 30-fold (1.48 log units) above the measured one; the whole stated range lies above it.
By their numbers in this assay, from the lowest: compound 4; then compounds 1, 2 and 3 (each within the scatter of the next).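

In this assay, this place on a double-bonded chain carbon bound to a double-bonded chain carbon proves able to shift the read-out far more than the earlier exchanges suggested, since 5-chloro-1H-indol-3-yl gives a 50-fold lower number from compound 3 to compound 4 (1.70 log units; beyond the scatter), together with a 50-fold lower number from compound 2 to compound 4 (1.70 log units; beyond the scatter) and a 25-fold lower number from compound 1 to compound 4 (1.40 log units; beyond the scatter). All three steps lie beyond the scatter, which makes compound 4 the strongest growth inhibitor of the four. The entering group brings in a six-membered aromatic ring, a chlorine and a hydrogen-bond donor together, so this one exchange cannot separate their contributions.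

Nothing available explains the size of this step. Going by these compounds, whether it would persist with an unsubstituted 1H-indol-3-yl, or with a methoxy group or an amine in place of the chlorine, stays open.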